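Sulfonyl aryl substituent in the shared core series

The compounds below may be only part of what the source reports. "The series", "measured", "known", "first", "only" and "open" are said of these compounds alone.

Three compounds with the same core have numbers in a functional assay on SMMC-7721 cells (Homo sapiens) for antiproliferative activity, read by MTT assay, with a stated time of 72 h; on this read-out lower numbers stand for stronger inhibition and higher numbers for weaker inhibition. Compound 1 `CC(=O)N(C)c1ccc2[nH]c(-c3n[nH]c4ccccc34)cc2n1` gives 23400 nM, compound 2 `COc1cccc(C(=O)N(C)c2ccc3[nH]c(-c4n[nH]c5ccccc45)cc3n2)c1` gives 22000 nM, and compound 3 `Cc1ccc(S(=O)(=O)N(C)c2ccc3[nH]c(-c4n[nH]c5ccccc45)cc3n2)cc1` gives 16300 nM. Exchanging the group on the ring nitrogen moves little: a 1.1-fold lower number from compound 1 to compound 2 (0.03 log units; within the scatter), a 1.4-fold lower number from compound 1 to compound 3 (0.16 log units; within the scatter) and a 1.3-fold lower number from compound 2 to compound 3 (0.13 log units; within the scatter) all lie within the scatter, so the three values cannot be separated, and compound 3 merely gives the number from which the next step starts.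

Compound 4 `CN(c1ccc2[nH]c(-c3n[nH]c4ccccc34)cc2n1)S(=O)(=O)c1ccc(Br)cc1` differs from compound 3 by bromo in place of methyl on an aromatic carbon; the (4-methylphenyl)sulfonyl becomes (4-bromophenyl)sulfonyl. Going by the values given here, none of the measured steps alters a substituent on this aromatic ring, so no step bears on the change directly; the steps that exist in this assay are all within the scatter. The expectation is therefore a step of a 1.1-fold lower number from compound 3 to compound 4 (0.04 log units; within the scatter), with no movement beyond the scatter. Compound 4 is estimated at 15000 nM in this assay, within the range 7000 nM to 35000 nM.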

Compound 4, half-maximal inhibitory concentration: 11500 nM
For compound 4 the middle estimate is 1.3-fold (0.12 log units) above the measured one; measured number inside the range.
By their numbers in this assay, from the lowest: compounds 4, 3, 2 and 1 (each within the scatter of the next, the first and the last beyond it).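

In this assay, going by these compounds alone, 4-methylphenyl to 4-bromophenyl is the first change read on a substituent of this aromatic ring, and it gives a 1.4-fold lower number from compound 3 to compound 4 (0.15 log units; within the scatter), so bromo and methyl on this aromatic carbon cannot be separated. Within the data shown here, the comparison with the carbonyl group of compound 2 also stays unresolved, with a 1.9-fold lower number from compound 2 to compound 4 (0.28 log units; within the scatter), whereas a 2.0-fold lower number from compound 1 to compound 4 (0.31 log units; beyond the scatter) is the first step to pass the scatter, and only modestly, making acetyl and (4-bromophenyl)sulfonyl on the nitrogen the one pair that separates. No available evidence bears on these steps.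

On these data alone, it remains open whether an amine or a carboxylic acid on the same aromatic carbon would move the number beyond the scatter from compound 3. Also open, as far as these compounds go, is how a longer chain in place of the methyl on the nitrogen would change the value of compound 4.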